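Triazole aryl swaps on the cinnamic acid series

This account rests on a few compounds, and the source may have more. Where it says the series, first, only, none or still open, it means among the compounds named here.

Compound 1 `COc1ccc(/C=C\C(=O)O)c(OCc2cn(-c3cccc(C#N)c3)nn2)c1CC=C(C)C` in a functional assay on HCT-116 cells (Homo sapiens) for cytotoxicity, read by MTT assay, with a stated time of 24 h (a higher number here means a weaker inhibitor, a lower number a stronger inhibitor), gives 35300 nM. Compound 2 `COc1ccc(/C=C\C(=O)O)c(OCc2cn(-c3cccnc3Cl)nn2)c1CC=C(C)C` gives 23000 nM in this assay, within the scatter of compound 1; the two numbers cannot be ordered. Compound 3 `COc1ccc(/C=C\C(=O)O)c(OCc2cn(-c3nc4ccccc4s3)nn2)c1CC=C(C)C` carries 1,3-benzothiazol-2-yl in place of 2-chloropyridin-3-yl on an aromatic nitrogen. Among the measured compounds shown here, the only step that bears on this change is a 1.5-fold lower number from compound 1 to compound 2 (0.19 log units; within the scatter), itself within the scatter, so a swap of the aryl group on the triazole nitrogen has so far moved nothing. For compound 3 the expectation is accordingly a 1.0-fold lower number from compound 2 to compound 3 (0.02 log units; within the scatter), a step of no size beyond the scatter. The estimate for compound 3 is 22000 nM, within 7000 nM to 70000 nM.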

Compound 3, half-maximal inhibitory concentration: 16400 nM
For compound 3 the middle estimate is 1.3-fold (0.13 log units) above the measured one, and the stated range covers the measured number.
By their numbers in this assay, from the lowest: compounds 3, 2 and 1 (each within the scatter of the next, the first and the last beyond it).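

Among the compounds shown here, at this position on the aromatic nitrogen, 1,3-benzothiazol-2-yl gives the first step beyond the scatter, a 2.2-fold lower number from compound 1 to compound 3 (0.33 log units; beyond the scatter), though the size is modest. Against 2-chloropyridin-3-yl the same group stays within the scatter, a 1.4-fold lower number from compound 2 to compound 3 (0.15 log units; within the scatter), so the aryl swap registers only against 3-cyanophenyl and all three compounds remain in one narrow band. No measurement on hand accounts for this step.

Still open, from the compounds shown here alone, is whether a plain phenyl or an aminoalkyl chain on this nitrogen would leave that band in this assay. Also open, going by these compounds, is how a methyl ester in place of the carboxylic acid would read with 1,3-benzothiazol-2-yl held constant.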